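A few compounds are considered here, and "the series" means these few. Any claim that something is new, unique, unknown or untested is made for them only; others in the source may bear on it.

Measured compounds:
Compound 1: `CS(=O)(=O)c1ccc(Cc2nnc3n2N=C(c2cc(Cl)sc2S(N)(=O)=O)CS3)cc1` — 22.8%
Compound 2: `CS(=O)(=O)c1ccc(Cc2nnc3n2N=C(c2cc(Cl)sc2Cl)CS3)cc1` — "not active" (no number reported)

In a functional assay on RAW264.7 cells (Mus musculus) for cytotoxicity, read by MTT assay, with a stated time of 48 h, tested at 12.5 uM (a higher number here means a stronger effect of the compound at the concentration tested, a lower number a weaker effect), compound 1 gives 22.8%. Among the measured compounds shown here, compound 2 stands differently: in this assay compound 2 is reported as "not active" (no number reported), so no single number is available for it, and no step between compound 1 and compound 2 is given. Compound 3, `CS(=O)(=O)c1ccc(Cc2nnc3n2N=C(c2ccc(Cl)cc2Cl)CS3)cc1`, has not yet been measured. It differs from compound 2 in one place: 2,4-dichlorophenyl in place of 2,5-dichlorothiophen-3-yl on a carbon with a double bond to nitrogen. For the measured compounds named here, with no measured step available for this kind of change, the size of the step from compound 2 to compound 3 in this assay cannot be drawn from the data; the expectation is that it stays within the usual scatter, with no clear direction. For compound 3 the estimated effect in this assay is 10%, within a range from 0% to 25%.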

Compound 3, a percentage reported as activity, at one concentration (the size of the read-out at that concentration, not a potency): 28%
Compound 3: middle estimate off by 18 percentage points, on the low side, and the stated range ends below it.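

In this assay compound 3 with 2,4-dichlorophenyl on the carbon with a double bond to nitrogen gives 28% as a number, while compound 2 with 2,5-dichlorothiophen-3-yl in that place is reported as "not active" (no number reported) and so the step between these two cannot be read. The comparison with the 5-chloro-2-sulfamoylthiophen-3-yl group shows a number 5.2 percentage points higher from compound 1 to compound 3 (within the scatter) and so this read-out does not separate that group from 2,4-dichlorophenyl. Nothing available explains why compound 2 and compound 3 are reported differently.

On these data alone, whether an unsubstituted phenyl ring, a pyridine ring or a phenyl ring bearing an amine would give a number in this place remains open. So does how the effect of these compounds changes with concentration.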